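Cytotoxicity tolerance across the thiophene-methylamine series

The source may hold more compounds than are shown below. What is called first, only, known or untested is meant among the compounds shown, and "the series" means these compounds.

Two compounds of this series carry a measured tolerance so far. In an ADME assay on MDCK cells (Canis lupus familiaris) for cytotoxicity, read by microscopy, with a stated time of 48 h (a higher number here means that more compound is tolerated, a lower number that less compound is tolerated), compound 1 `CCc1ccc(CN[C@@H]2C[C@H]3C[C@@H]([C@H]2C)C3(C)C)s1` gives 1560 nM, while compound 2 `CCCc1csc(CN[C@@H]2C[C@H]3C[C@@H]([C@H]2C)C3(C)C)c1` gives 12500 nM. Of the two numbers compound 2 stands highest, and its gap to compound 1 lies beyond the scatter, so compound 2 is the better tolerated of the pair. Within the data shown here, no single-site step between the measured compounds is available, so the effect of any one change on this assay remains untested here.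

Compound 3 `C[C@H]1[C@H](NCc2cc(C3CCCCC3)cs2)C[C@H]2C[C@@H]1C2(C)C` differs from compound 2 in one place: cyclohexyl in place of propyl on an aromatic carbon. Among the measured compounds shown here, with no measured step to lean on, a moderate movement in either direction cannot be ruled out; a move toward lower tolerance is expected, of a size close to the scatter. Compound 3 is estimated at 6000 nM, within 1500 nM to 25000 nM, an expected step from compound 2 of a 2.1-fold lower number from compound 2 to compound 3 (0.32 log units; beyond the scatter).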

Compound 3, minimum cytotoxic concentration: 780 nM
For compound 3 the middle estimate is 7.7-fold (0.89 log units) above the measured one; measured number below the stated range.
By their numbers in this assay, from the lowest: compounds 3 and 1 (each within the scatter of the next); then compound 2.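

In this assay, among these compounds, the exchange of propyl for cyclohexyl, two ring bonds from the ring sulfur, brings a 16-fold lower number from compound 2 to compound 3 (1.20 log units; beyond the scatter) and gives the first single-site reading. This position is therefore not indifferent to the group it carries: tolerance falls markedly when an open chain gives way to a six-membered non-aromatic ring of carbon only, although neither group has a hydrogen-bond donor or acceptor. Nothing measured on these compounds accounts for the step.

From the compounds shown here alone, whether the fall follows the ring itself or simply the larger carbon group remains open; a hexyl chain or a cyclopropyl ring at this position would help separate the two. Also open, going by these compounds, is how a group containing oxygen or nitrogen, such as a methoxy group or a morpholine, would read here.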